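This account rests on a few compounds, and the source may have more. Where it says the series, first, only, none or still open, it means among the compounds named here.

Measured compounds in a functional assay on SMMC-7721 cells (Homo sapiens) for cytotoxicity, read by MTT assay, with a stated time of 24 h; a lower number here means a stronger inhibitor, a higher number a weaker inhibitor:
compound 1 `O=C1/C(=C/c2ccccc2F)CN(S(=O)(=O)c2ccc(F)cc2)C/C1=C\c1ccccc1F`, compound 1 gives 7700 nM
compound 2 `O=C1/C(=C/c2cccc(F)c2)CN(S(=O)(=O)c2ccccc2)C/C1=C\c1cccc(F)c1`, compound 2 gives 12900 nM
compound 3 `O=C1/C(=C/c2cccc(F)c2)CN(S(=O)(=O)c2ccc(Cl)cc2)C/C1=C\c1cccc(F)c1`, compound 3 gives 7800 nM

Compound 3 sits second highest of the three numbers in this assay. Its nearest neighbour is compound 1, whose number is all but the same and lies within the scatter; its furthest is compound 2, and even that gap is within the scatter, so no order among the three can be read from these numbers.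

The step to compound 4 `CC(=O)Nc1ccc(S(=O)(=O)N2C/C(=C\c3cccc(F)c3)C(=O)/C(=C/c3cccc(F)c3)C2)cc1` changes the sulfonyl aryl group: acetamido in place of chloro on an aromatic carbon. Within the data shown here, only one measured step touches this position, a 1.7-fold lower number from compound 2 to compound 3 (0.22 log units; within the scatter), and it stayed within the scatter. Among the measured compounds shown here, no measured step shows what an acetamido group does on this ring, so the data give no basis for expecting a move beyond the scatter in this assay in either direction. Compound 4 is therefore estimated to give about 9000 nM, with a range of 3500 nM to 25000 nM. The expected step is a 1.2-fold higher number from compound 3 to compound 4 (0.06 log units; within the scatter), a value close to that of compound 3, 7800 nM, with wide uncertainty.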

Compound 4, half-maximal inhibitory concentration: 10300 nM
Estimate against measurement, compound 4: 1.1-fold (0.06 log units) below, within the range that was stated.
By their numbers in this assay, from the lowest: compounds 1, 3, 4 and 2 (each within the scatter of the next).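

At the place para to a large group on the sulfonyl aryl ring, the earlier compounds had shown only chloro and hydrogen, and compound 4 adds a much larger substituent, acetamido, which brings a hydrogen-bond donor and a hydrogen-bond acceptor that chloro lacks. In this assay that exchange gives a 1.3-fold higher number from compound 3 to compound 4 (0.12 log units; within the scatter) and, set against the unsubstituted ring, a 1.3-fold lower number from compound 2 to compound 4 (0.10 log units; within the scatter), so neither step can be read as a gain or a loss, and the position has now taken three different substituents with no step beyond the scatter. No measurement given here accounts for this result, and nothing offers a cause for it.

On these data alone, what an amine, a carboxylic acid or a longer chain such as butyramido would do at this place remains open, as does whether any group here can move the number beyond the scatter. Also open, as far as these compounds go, is whether the acetamido group would behave the same way with the fluoro groups placed as in compound 1, since compounds 2, 3 and 4 share one arrangement of them.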